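Swapping a Butynyl Ester for an Aryl Amide

The compounds below may be only part of what the source reports. "The series", "measured", "known", "first", "only" and "open" are said of these compounds alone.

In a functional assay on Caco-2 cells (Homo sapiens) for antiproliferative activity, read by MTT assay, with a stated time of 48 h (a higher number here means a weaker inhibitor, a lower number a stronger inhibitor), compound 3 `C#CCCOC(=O)c1ccc(C(CC)(CC)c2ccc(OCCC(O)(CC)CC)c(C)c2)n1CC` reads > 50000 nM, a limit of the assay and not a number. Compound 1 `CCn1c(C(=O)NCC#N)ccc1C(CC)(CC)c1ccc(OCCC(O)(CC)CC)c(C)c1` reads > 50000 nM, also a limit. Compound 2 `CCn1c(C(=O)N(CCC#N)CCC#N)ccc1C(CC)(CC)c1ccc(OCCC(O)(CC)CC)c(C)c1` reads > 50000 nM, again a limit. Within the data shown here, the only evidence so far is the limit of > 50000 nM in this assay, at which 3 of the 3 values shown sit. Compound 4 `CCn1c(C(=O)Nc2ccc(OC(F)(F)F)cc2)ccc1C(CC)(CC)c1ccc(OCCC(O)(CC)CC)c(C)c1` changes one group: (4-(trifluoromethoxy)phenyl)amino in place of (but-3-yn-1-yl)oxy on a carbonyl carbon. Two measured changes on that same carbonyl carbon bear on this: a step that the two limits leave unreadable from compound 1 to compound 3 and a step that the two limits leave unreadable from compound 2 to compound 3. Among the measured compounds shown here, neither gives a size or direction, and none of the measured groups has a ring. A small gain in this assay is therefore the most that is expected, and the reading may stay at the limit. The expected change is an at least 1.6-fold lower number from compound 3 to compound 4 (0.22 log units; that floor lies within the scatter). For compound 4 the estimated value is 30000 nM, with an expected range from 8000 nM to 50000 nM.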

Compound 4, half-maximal inhibitory concentration: > 50000 nM
Compound 4: no number, only a limit; the forecaster's own chance of this, stated with the estimate: 60%; middle value at least 1.6-fold (0.22 log units) away from the limit.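

Among these compounds, compound 1, compound 2, compound 3 and compound 4 all sit at a limit in this assay, so no step between them can be read. The compounds shown leave open whether any group on the carbonyl carbon can bring the reading to a real number: the limit of > 50000 nM in this assay, at which 4 of the 4 values shown sit.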